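The source may hold more compounds than are shown below. What is called first, only, known or untested is meant among the compounds shown, and "the series" means these compounds.

Series notes. Going by the values given here, the three compounds measured so far share one core and differ only in the aryl group on the carbonyl carbon of the amide. Compound 1 `O=C(Nc1cccc(-c2oc3cc(-c4ccc(F)cc4)ccc3c(=O)c2O)c1)c1ccccc1F` gives 17400 nM in a functional assay on GTL 16 cells for antiproliferative activity against GTL 16 cell line (Homo sapiens), read by CCK-8 assay, with a stated time of 72 h; on this read-out lower numbers stand for stronger inhibition and higher numbers for weaker inhibition. Compound 2 `O=C(Nc1cccc(-c2oc3cc(-c4ccc(F)cc4)ccc3c(=O)c2O)c1)c1ccc(F)cc1` gives 14600 nM in this assay, and compound 3 `O=C(Nc1cccc(-c2oc3cc(-c4ccc(F)cc4)ccc3c(=O)c2O)c1)c1ccc(Cl)cc1` gives 9140 nM in this assay. Compound 3 carries the lowest of the three recorded numbers, but its steps to the others, a 1.6-fold lower number from compound 2 to compound 3 (0.20 log units; within the scatter) and a 1.9-fold lower number from compound 1 to compound 3 (0.28 log units; within the scatter), both lie within the scatter, so no ranking among the three is claimed.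

Compound 4 `O=C(Nc1cccc(-c2oc3cc(-c4ccc(F)cc4)ccc3c(=O)c2O)c1)c1ccc(F)cc1F` is not yet measured. It differs from compound 3 by 2,4-difluorophenyl in place of 4-chlorophenyl on a carbonyl carbon. Among the compounds with values here, two measured steps bear on this change: a 1.6-fold lower number from compound 2 to compound 3 (0.20 log units; within the scatter), which runs the opposite way to the chloro-to-fluoro part of the present change, and a 1.2-fold lower number from compound 1 to compound 2 (0.08 log units; within the scatter), which compares the two fluorophenyl groups whose substitution compound 4 combines. Both steps were within the scatter. The expectation is therefore a step of a 1.6-fold higher number from compound 3 to compound 4 (0.22 log units; within the scatter), toward a higher number but not beyond the scatter. Compound 4 is estimated at 15000 nM in this assay, with an expected range from 7500 nM to 30000 nM.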

Compound 4, half-maximal inhibitory concentration: 9640 nM
The estimate for compound 4 lay 1.6-fold (0.19 log units) above the measured number; measured number inside the range.
By their numbers in this assay, from the lowest: compounds 3, 4, 2 and 1 (each within the scatter of the next).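

In this assay, 2,4-difluorophenyl in place of 4-chlorophenyl on the carbonyl carbon gives a 1.1-fold higher number from compound 3 to compound 4 (0.02 log units; within the scatter), so this exchange, which alters both the halogen and the number of halogens on the ring, produces no step beyond the scatter. Fluoro in place of hydrogen on the two single-fluoro rings gives a 1.5-fold lower number from compound 2 to compound 4 (0.18 log units; within the scatter) and a 1.8-fold lower number from compound 1 to compound 4 (0.26 log units; within the scatter), so the second fluoro, read from either side, also leaves the number within the scatter, which the earlier compounds, each with a single halogen on this ring, could not show. No measurement at hand bears on why these numbers lie so close together.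

All four compounds carry a halogen-substituted phenyl group at this position, so the set shows only that these halogen patterns do not separate from one another, not whether this position can move the number at all. A phenyl ring bearing an amine or a carboxylic acid, or a longer alkyl chain in place of the phenyl ring, would test whether any change on this carbonyl carbon gives a step beyond the scatter.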